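The source may hold more compounds than are shown below. What is called first, only, known or untested is meant among the compounds shown, and "the series" means these compounds.

Measured compounds:
- Compound 1, `Cc1nc(N)c2nc(-c3ccccc3)sc2n1`: 2660 nM in an assay on CHO cells for displacement of a labelled ligand from adenosine receptor A3 (Homo sapiens), read by scintillation counting, with a stated time of 3 h; a higher number here means a weaker inhibitor, a lower number a stronger inhibitor
- Compound 2, `Nc1nc(-c2ccc(CO)cc2)nc2sc(-c3ccco3)nc12`: 3.58 nM
- Compound 3, `Cc1nc(NC(=O)c2ccccc2)c2nc(-c3ccccc3)sc2n1`: 691 nM

Compound 3 stands second highest of the three numbers. Its nearest neighbour is compound 1, which gives 2660 nM; the step of a 3.8-fold lower number from compound 1 to compound 3 (0.59 log units; beyond the scatter) is modest and beyond the scatter. Compound 2, with a different core decoration, gives 3.58 nM, far lower than compound 3.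

Compound 4, `COc1ccc(C(=O)Nc2nc(C)nc3sc(-c4ccccc4)nc23)cc1`, differs from compound 3 by one change: methoxy in place of hydrogen on an aromatic carbon. Among the measured compounds shown here, no measured pair shows this change, so nothing bears on it directly; the only measured step, a 3.8-fold lower number from compound 1 to compound 3 (0.59 log units; beyond the scatter), concerns the benzoyl group itself rather than a substituent on it. With no evidence either way, the expected step of a 1.3-fold lower number from compound 3 to compound 4 (0.10 log units; within the scatter) is small, within the scatter. Compound 4 is therefore estimated at 550 nM, with a range of 150 nM to 2000 nM.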

Compound 4, inhibition constant: 91 nM
Beside the measured number, compound 4's estimate is 6.0-fold (0.78 log units) above it, outside the stated range (below it).
By their numbers in this assay, from the lowest: compound 2; then compound 4; then compound 3; then compound 1.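

In this assay, the change from phenyl to 4-methoxyphenyl gives a 7.6-fold lower number from compound 3 to compound 4 (0.88 log units; beyond the scatter), so this carbon of the six-membered aromatic ring is not a neutral place for substitution. The earlier compounds shown here showed only what adding the benzoyl group itself does, a 3.8-fold lower number from compound 1 to compound 3 (0.59 log units; beyond the scatter), whereas this step shows that a methoxy group on that benzoyl group can move the number further, beyond the scatter. No measurement here explains why the number falls.

The compounds shown leave open whether the step belongs to methoxy in particular, since no other group, such as a hydroxyl, an amine, a chlorine or the longer ethoxy, stands at this place. They also leave open whether methoxy would give a similar step on another carbon of the same ring.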